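The compounds below may be only part of what the source reports. "The series", "measured", "known", "first", "only" and "open" are said of these compounds alone.

Compound 1, `Nc1nc(N)c2c(-c3ccsc3)cn([C@@H]3O[C@H](CO)[C@@H](O)[C@H]3O)c2n1`, in a functional assay on A549 cells (Homo sapiens), read by MTT assay, with a stated time of 72 h (on this read-out higher numbers stand for weaker inhibition and lower numbers for stronger inhibition), reaches only a limit, > 100000 nM.
Compound 2, `C#Cc1cn([C@@H]2O[C@H](CO)[C@@H](O)[C@H]2O)c2nc(C)nc(N)c12`, in this assay reaches only a limit, > 20000 nM.
Compound 3, `Cc1nc(N)c2c(-c3cc4ccccc4o3)cn([C@@H]3O[C@H](CO)[C@@H](O)[C@H]3O)c2n1`, in this assay reaches only a limit, > 20000 nM.

All three values shown are limits, so compound 3 cannot be placed against the others: it sits at the limit of > 20000 nM in this assay, at which 2 of the 3 values shown sit, where compound 2 also sits, while compound 1 sits at the limit of > 100000 nM in this assay, at which 1 of the 3 values shown sits. For the measured compounds named here, the one step among measured compounds, a step that the two limits leave unreadable from compound 2 to compound 3, is therefore unreadable, and it is the only measured step that touches compound 3.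

Compound 4, `Cc1nc(N)c2c(-c3ccsc3)cn([C@@H]3O[C@H](CO)[C@@H](O)[C@H]3O)c2n1`, differs from compound 3 in one place: thiophen-3-yl in place of 1-benzofuran-2-yl on an aromatic carbon. Going by the values given here, no measured step bears on this change. Among the compounds with values here, compound 1 carries the same thiophen-3-yl ring on the same carbon, but its core differs from that of compound 4 in another place, so its limit shows only that such a ring did not yield a readable value there.

Compound 4 is therefore expected to give a limit again, with an estimated 50000 nM and a range of 15000 nM to 300000 nM. The step from compound 3 to compound 4 is expected to be a step that the limit leaves unreadable from compound 3 to compound 4, nothing beyond scatter.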

Compound 4, half-maximal inhibitory concentration: > 20000 nM
Compound 4 gave a limit, no number (the forecaster's own chance of this, stated with the estimate: 85%); the middle value is on the limit's open side.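

Compound 4, like compound 1, compound 2 and compound 3, reaches only a limit in this assay, and none of the steps to compound 4 from those three can be read. The compounds shown leave open whether any group on this carbon gives a readable value.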